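The source may report more compounds than this note shows. Statements on the series, on what has been measured and on what is new or still open speak of the compounds shown alone.

Compound 1, `CS(=O)(=O)Nc1ccc2c(c1)S(=O)(=O)C=C(c1c(O)c3ccccc3n(Cc3ccc(F)cc3)c1=O)N2`, is tested in an ADME assay on 2209-23 cells (Homo sapiens) for cytotoxicity, read by WST assay (a higher number here means that more compound is tolerated, a lower number that less compound is tolerated), and there compound 1 gives only a limit of > 50000 nM. Its two measured neighbours sit at the same place. Compound 2, `CS(=O)(=O)Nc1ccc2c(c1)S(=O)(=O)C=C(c1c(O)c3c(Cl)cccc3n(Cc3ccc(F)cc3)c1=O)N2`, gives a limit of > 50000 nM in this assay. Compound 3, `Cc1ccc2c(c1)c(O)c(C1=CS(=O)(=O)c3cc(NS(C)(=O)=O)ccc3N1)c(=O)n2Cc1ccc(F)cc1`, gives a limit of > 50000 nM in this assay. The step that the two limits leave unreadable from compound 1 to compound 2 is chloro in place of hydrogen on an aromatic carbon, and the step that the two limits leave unreadable from compound 1 to compound 3 is methyl in place of hydrogen on an aromatic carbon; neither step has a readable size because of the limit of > 50000 nM in this assay, at which 3 of the 3 values shown sit.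

Compound 4, `CS(=O)(=O)Nc1ccc2c(c1)S(=O)(=O)C=C(c1c(O)c3cccc(F)c3n(Cc3ccc(F)cc3)c1=O)N2`, differs from compound 1 by fluoro in place of hydrogen on an aromatic carbon. Among the measured compounds shown here, the two measured steps that bear on this change, each a single small substituent entering in place of hydrogen, left no readable size, so no step of known magnitude is available to set an expectation in either direction. Compound 4 is therefore expected to stay at the limit in this assay, with an expected step that the limit leaves unreadable from compound 1 to compound 4 that is not beyond the scatter. The estimate for compound 4 in this assay is 80000 nM, in a range from 40000 nM to 200000 nM.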

Compound 4, half-maximal cytotoxic concentration: > 50000 nM
Compound 4 ended at the assay's limit; the forecaster's own chance of this, stated with the estimate: 85%; the middle value is on the limit's open side.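

Compound 1 and compound 4 both stand at a limit in this assay, so no size can be read for the step between them: the limit of > 50000 nM in this assay, at which 4 of the 4 values shown sit.

The compounds shown leave open whether chloro, methyl or fluoro in place of hydrogen changes the tolerated concentration at all.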